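Serum Stability of Fluoropyrimidine Nucleoside Phosphate Esters

This account rests on a few compounds, and the source may have more. Where it says the series, first, only, none or still open, it means among the compounds named here.

Four related compounds are compared here. Compound 1 `O=C(O[C@H]1C[C@H](n2cc(F)c(=O)[nH]c2=O)O[C@@H]1COP(=O)(O)Oc1cccnc1)c1ccccc1` and compound 2 `O=C(O[C@H]1C[C@H](n2cc(F)c(=O)[nH]c2=O)O[C@@H]1COP(=O)(O)Oc1ccc2ncccc2c1)c1ccccc1` share a core in which the sugar oxygen carries a benzoyl group, and compound 3 `O=c1[nH]c(=O)n([C@H]2C[C@H](O)[C@@H](COP(=O)(O)Oc3cccnc3)O2)cc1F` and compound 4 `O=c1[nH]c(=O)n([C@H]2C[C@H](O)[C@@H](COP(=O)(O)Oc3ccc4ncccc4c3)O2)cc1F` share a second core; the two cores differ by hydrogen in place of benzoyl on an oxygen on a saturated carbon. In an ADME assay on a cell-free system (serum, Homo sapiens) for metabolic stability, read by HPLC, tested at 2 mM (on this read-out higher numbers stand for a longer-lived compound and lower numbers for a shorter-lived compound), compound 1 gives 17.8 h, compound 2 gives 16.5 h and compound 3 gives 19.9 h.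

The change from compound 1 to compound 2 is quinolin-6-yl in place of pyridin-3-yl on an oxygen, and it made a 1.1-fold lower number from compound 1 to compound 2 (0.03 log units; within the scatter). The change between the cores, from compound 1 to compound 3, made a 1.1-fold higher number from compound 1 to compound 3 (0.05 log units; within the scatter). Compound 4 is not yet measured. Within the data shown here, it differs from compound 3 by quinolin-6-yl in place of pyridin-3-yl on an oxygen, which is the same change as the one from compound 1 to compound 2, at the same kind of place.

In this assay the step from compound 3 to compound 4 is expected to be a 1.1-fold lower number from compound 3 to compound 4 (0.03 log units; within the scatter), resting on the earlier step of a 1.1-fold lower number from compound 1 to compound 2 (0.03 log units; within the scatter). Compound 4 is therefore estimated at 18.5 h, with an expected range from 12 h to 29 h.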

Compound 4, half-life in the Homo sapiens assay: 26.2 h
For compound 4 the middle estimate is 1.4-fold (0.15 log units) below the measured one; the measured number falls inside the stated range.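

In the Homo sapiens assay, quinolin-6-yl in place of pyridin-3-yl on the second core makes a 1.3-fold higher number from compound 3 to compound 4 (0.12 log units; within the scatter), and this step agrees with the earlier one on the benzoyl core: the same change on two cores in the Homo sapiens assay, a 1.1-fold lower number (0.03 log units; within the scatter) from compound 1 to compound 2 and a 1.3-fold higher number (0.12 log units; within the scatter) from compound 3 to compound 4, 1.4-fold (0.15 log units) apart, within the scatter of two such steps

Hydrogen in place of benzoyl, now read with quinolin-6-yl on the phosphate, gives a 1.6-fold higher number from compound 2 to compound 4 (0.20 log units; within the scatter), and this step also agrees with its earlier counterpart: the same change on two cores in the Homo sapiens assay, a 1.1-fold higher number (0.05 log units; within the scatter) from compound 1 to compound 3 and a 1.6-fold higher number (0.20 log units; within the scatter) from compound 2 to compound 4, 1.4-fold (0.15 log units) apart, within the scatter of two such steps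

In a physicochemical assay for metabolic stability, read by HPLC, tested at 2 mM (a higher number here means that the compound lasts longer, a lower number that the compound disappears faster), compound 3 gives 16.7 h and compound 4 gives 26 h, and these two values lie within the scatter of each other.

Within these four compounds, each change therefore carries from one core to the other, but only in the limited sense that all four steps are too small to stand out from the scatter, so this agreement shows neither that either change truly shifts the half-life nor that a larger effect would carry over in the same way.

The compounds shown leave open how a different group would behave on the oxygen whose other neighbour is phosphorus, such as a plain phenyl or a longer alkyl chain. They also leave open whether a smaller acetyl group in place of benzoyl would fit the same picture.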